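Trifluoromethyl in Place of a Larger Group: Compound 4

The source may report more compounds than this note shows. Statements on the series, on what has been measured and on what is new or still open speak of the compounds shown alone.

Compound 1 `CC(O)(CSc1cccc(S(F)(F)(F)(F)F)c1)C(=O)Nc1ccc(S(F)(F)(F)(F)F)cc1` is the starting point. In a functional assay on LNCaP cells (Homo sapiens) for antiproliferative activity, read by propidium iodide staining, with a stated time of 96 h (on this read-out lower numbers stand for stronger inhibition and higher numbers for weaker inhibition), compound 1 gives 25000 nM. Compound 2 `CC(O)(CSc1cccc(C(F)(F)F)c1)C(=O)Nc1ccc(S(F)(F)(F)(F)F)cc1` carries a group of 4 heavy atoms (1 carbon, 3 fluorine; no ring) in place of a group of 6 heavy atoms (5 fluorine, 1 sulfur; no ring), on an aromatic carbon and in this assay compound 2 gives 18300 nM, which is a 1.4-fold lower number from compound 1 to compound 2 (0.14 log units; within the scatter). Compound 3 `CC(O)(COc1cccc(S(F)(F)(F)(F)F)c1)C(=O)Nc1ccc(S(F)(F)(F)(F)F)cc1` has a different core; how its core differs from that of compound 1 is not broken down here. In this assay compound 3 gives 12000 nM, the lowest of the three numbers, though its gap to compound 2 lies within the scatter. Compound 4 `CC(O)(COc1cccc(C(F)(F)F)c1)C(=O)Nc1ccc(S(F)(F)(F)(F)F)cc1` is not yet measured and carries a group of 4 heavy atoms (1 carbon, 3 fluorine; no ring) in place of a group of 6 heavy atoms (5 fluorine, 1 sulfur; no ring), on an aromatic carbon, the same change as between compound 1 and compound 2. The expected step is a 1.3-fold lower number from compound 3 to compound 4 (0.12 log units; within the scatter), because the same change gave a 1.4-fold lower number from compound 1 to compound 2 (0.14 log units; within the scatter) on the other core. Compound 4 is therefore expected to give about 9000 nM. For compound 4 the estimate is expected to fall between 4000 nM and 20000 nM.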

Compound 4, half-maximal inhibitory concentration: 24700 nM
Estimate against measurement, compound 4: 2.7-fold (0.44 log units) below; measured number above the stated range.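

On the core of compound 3, trifluoromethyl in place of the larger group gives a 2.1-fold higher number from compound 3 to compound 4 (0.31 log units; beyond the scatter) in this assay. Set beside the earlier step, this shows that the change does not carry over unchanged between these two cores: the same change on two cores in this assay, a 1.4-fold lower number (0.14 log units; within the scatter) from compound 1 to compound 2 and a 2.1-fold higher number (0.31 log units; beyond the scatter) from compound 3 to compound 4, 2.8-fold (0.45 log units) apart, beyond the scatter of two such steps. For the compounds shown here, with only one pair on each core, this does not show why the two steps part, or how the same change would behave on any further core.

As far as these compounds go, it stays open whether a nitrile or a chlorine atom on that aromatic carbon would also give different steps on the two cores. Also open, from the compounds shown here alone, is how an amine linker in place of the sulfur or oxygen would affect the change.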